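A few compounds are considered here, and "the series" means these few. Any claim that something is new, unique, unknown or untested is made for them only; others in the source may bear on it.

Compound 1, with the structure `CN(C)C(=O)/C=C1\CCc2ccc(F)cc21`, gives 100% in a functional assay on the whole organism with Mus musculus as the target, at a dose of 100 mg/kg by the intraperitoneal route; a higher number here means more inhibition at the dose given (going by the name of the read-out), a lower number less inhibition. Compound 2, `CNC(=O)/C=C1\CCc2cc(F)c(F)cc21`, gives 100% in this assay, and compound 3, `CN(C)C(=O)/C=C1\CCc2c(F)cc(F)cc21`, gives 100%. Compound 1 is therefore level with compounds 2 and 3 at the digits shown. Among the compounds with values here, the one single-point step measured so far is no change at the digits printed from compound 1 to compound 3 (within the scatter), and it concerns fluoro in place of hydrogen on an aromatic carbon, not the amide end of the molecule. Compound 4, `O=C(/C=C1\CCc2ccc(F)cc21)NCC1CC1`, differs from compound 1 by (cyclopropylmethyl)amino in place of dimethylamino on a carbonyl carbon. Within the data shown here, no measured step touches that part, so the expectation rests on the shared high level of compounds 1, 2 and 3, and compound 4 is estimated to give 90%, between 60% and 100%, a step of a number 10 percentage points lower from compound 1 to compound 4 (within the scatter).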

Compound 4, a percentage reported as inhibition, in the whole organism at one dose (the size of the read-out at that dose, not a potency): 50%
Compound 4: the middle estimate sits 40 percentage points above what was measured; measured number below the stated range.
By their numbers in this assay, from the lowest: compound 4; then compounds 1, 2 and 3 (each within the scatter of the next).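

The amide end of the molecule turns out to matter: in this assay, replacing dimethylamino with (cyclopropylmethyl)amino on the carbonyl carbon gives a number 50 percentage points lower from compound 1 to compound 4 (beyond the scatter), whereas fluoro on an aromatic carbon gave no change at the digits printed from compound 1 to compound 3 (within the scatter). This one change adds a three-membered ring and a hydrogen-bond donor and enlarges the group, so several differences travel together. Nothing available explains the fall.

On these data alone, it remains open which of these differences counts. A diethylamino or a propylamino group on the same carbonyl carbon would help to separate them.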